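The compounds below may be only part of what the source reports. "The series", "measured", "known", "first", "only" and "open" are said of these compounds alone.

Measured compounds, largest response in the agonist assay:

compound 1 `Cc1nc(-c2ccc(C(F)(F)F)cc2)sc1CNc1ccc(OCC(=O)O)cc1` — 100%
compound 2 `Cc1nc(-c2ccc(C(F)(F)F)cc2)sc1CNc1ccc(CC(C)C(=O)O)cc1` — 100%
compound 3 `Cc1nc(-c2ccc(C(F)(F)F)cc2)sc1CNc1ccc(C(C)CC(=O)O)cc1` — 109%

In a functional assay on CHO cells for agonist activity at Free fatty acid receptor 1 (Homo sapiens), read by a luciferase reporter (a higher number here means a larger maximal response, a lower number a smaller maximal response), compound 3 gives 109%, the highest of the three numbers, but its nearest neighbour compound 1 sits within the scatter (a number 9 percentage points higher from compound 1 to compound 3 (within the scatter)), as does compound 2 (a number 9 percentage points higher from compound 2 to compound 3 (within the scatter)), so the three compounds cannot be ordered. The step of no change at the digits printed from compound 1 to compound 2 (within the scatter) is likewise flat. All three carry a carboxylic acid on the aromatic carbon, and the moves between them show that the acid can be relocated without effect on the maximal response.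

Compound 4 `Cc1nc(-c2ccc(C(F)(F)F)cc2)sc1CNc1ccc([C@H]2C[C@@H]2C(=O)N(C)C)cc1` differs from compound 3 in that (2-(dimethylcarbamoyl)cyclopropyl in place of 1-(carboxymethyl)ethyl on an aromatic carbon). Going by the values given here, no measured step covers removal of the acid; the three flat steps only show tolerance among acid-bearing groups. The step in this assay to compound 4 is therefore poorly anchored, and a drop is estimated, a number 49 percentage points lower from compound 3 to compound 4 (beyond the scatter), with a wide spread. Compound 4 is expected at 60%, range 15% to 110%.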

Compound 4, largest response reached (reported as percent of maximum), in percent of the reference or control that the assay uses: 49%
For compound 4 the middle estimate is 11 percentage points above the measured one, and the stated range covers the measured number.
By their numbers in this assay, from the lowest: compound 4; then compounds 1, 2 and 3 (each within the scatter of the next).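

In this assay, going by these compounds alone, replacing 1-(carboxymethyl)ethyl with 2-(dimethylcarbamoyl)cyclopropyl on the aromatic carbon para to a large group gives a number 60 percentage points lower from compound 3 to compound 4 (beyond the scatter) and is the first step to lie beyond the scatter. The result is similar against the other two acid-bearing groups, with a number 51 percentage points lower from compound 2 to compound 4 (beyond the scatter) for 2-carboxypropyl and a number 51 percentage points lower from compound 1 to compound 4 (beyond the scatter) for carboxymethoxy as the group leaving, so a position that tolerates all three carboxylic acids does not tolerate this dimethylamide. No data at hand give a reason for the drop.

The change swaps the carboxylic acid for the amide and brings in the cyclopropyl ring and two defined stereocentres at once, and the compounds shown do not separate these. A 2-carboxycyclopropyl group and an open-chain dimethylcarbamoyl group would tell the contribution of the ring from that of losing the acid.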